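Iodo for ethyl on the urea aryl: compound 4

This account rests on a few compounds, and the source may have more. Where it says the series, first, only, none or still open, it means among the compounds named here.

Within the data shown here, compound 1 `CCc1ccccc1NC(=O)N[C@H](C)c1ccccc1` gives 92% in an ADME assay on the whole organism with Oryza sativa as the target, tested at 10 uM (a lower number here means a stronger effect, a higher number a weaker effect of the compound at the concentration tested), the second highest of the three numbers measured so far. Compound 2 `CCc1ccccc1NC(=O)N[C@@H](C)c1ccccc1` gives 95% and compound 3 `CC(C)c1ccc(NC(=O)N[C@@H](C)c2ccccc2)cc1` gives 86% in this assay. Among the measured compounds shown here, the only step with a single change, a number 3 percentage points higher from compound 1 to compound 2 (within the scatter), rests on the fact that compounds 1 and 2 differ only in the configuration as drawn and stays within the scatter. Compound 4 `C[C@@H](NC(=O)Nc1ccccc1I)c1ccccc1` differs from compound 1 by iodo in place of ethyl on an aromatic carbon. For the measured compounds named here, no measured step exchanges a substituent on the aromatic ring, so none bears directly on this change; the three numbers measured lie close together. Therefore no step beyond the scatter is expected, a number 2 percentage points lower from compound 1 to compound 4 (within the scatter). Compound 4 is estimated at 90% in this assay, with a range from 78% to 98%.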

Compound 4, a percentage reported as activity, at one concentration (the size of the read-out at that concentration, not a potency): 96%
Beside the measured number, compound 4's estimate is 6 percentage points below it; low and high end bracket the measured number.
By their numbers in this assay, from the lowest: compounds 3, 1, 2 and 4 (each within the scatter of the next).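

Among these compounds, on an aromatic carbon ortho to a large group, iodo in place of ethyl gives in this assay a number 4 percentage points higher from compound 1 to compound 4 (within the scatter) and so, for the first time in these compounds, tests a substituent exchange on this ring. At this place, one iodine atom replaces two carbons with no step beyond the scatter. Nothing shown bears on why this exchange leaves the number within the scatter. On these data alone, whether an amine or a carboxylic acid on this aromatic carbon would move the number beyond the scatter stays open.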